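This account rests on a few compounds, and the source may have more. Where it says the series, first, only, none or still open, it means among the compounds named here.

Notes on the series

The compounds share one core carrying a triazole whose aryl substituent is varied. Compound 1 `C=C1C[C@]23C[C@@]1(O)CC[C@H]2c1ccc(OS(=O)(=O)c2ccc(C)cc2)c(C)c1[C@@H]3Cn1cc(-c2ccc(OC)cc2)nn1` has a methoxyphenyl on the triazole and a tosylate on the phenol position. In a functional assay on HL-60 cells (Homo sapiens) for cytotoxicity, read by MTT assay, with a stated time of 4 days (on this read-out higher numbers stand for weaker inhibition and lower numbers for stronger inhibition), compound 1 gives only a limit, > 20000 nM, and no number. Compound 2 `C=C1C(=O)[C@]23C[C@@]1(O)CC[C@H]2c1ccc(O)c(C)c1[C@@H]3Cn1cc(-c2ccc(C(F)(F)F)cc2)nn1` keeps the free phenol and carries a trifluoromethylphenyl on the triazole. In this assay compound 2 gives 720 nM. Among the values shown, compound 2 holds the only number; the one other value is a limit, so compound 2 cannot be ranked against compound 1 beyond noting that its value is a number where the other is not (the limit of > 20000 nM in this assay, at which 1 of the 2 values shown sits).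

Compound 3 `C=C1C(=O)[C@]23C[C@@]1(O)CC[C@H]2c1ccc(O)c(C)c1[C@@H]3Cn1cc(-c2ccc(Br)cc2)nn1`, not yet measured, differs from compound 2 in one place: bromo in place of trifluoromethyl on an aromatic carbon. Among the measured compounds shown here, no measured step of this kind is available. The exchange is expected to leave the value close to that of compound 2, and the step from compound 2 to compound 3 is estimated as a 1.1-fold higher number from compound 2 to compound 3 (0.05 log units; within the scatter), not beyond the usual scatter in either direction. In this assay compound 3 is therefore expected at about 800 nM, with a range from 300 nM to 2500 nM.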

Compound 3, half-maximal inhibitory concentration: 560 nM
Estimate against measurement, compound 3: 1.4-fold (0.15 log units) above, and the stated range covers the measured number.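

In this assay, the series now has its first measured step at this position: bromo in place of trifluoromethyl on an aromatic carbon, para to a large group, gives a 1.3-fold lower number from compound 2 to compound 3 (0.11 log units; within the scatter), and the two compounds cannot be told apart on this read-out. The exchange of 4-(trifluoromethyl)phenyl to 4-bromophenyl replaces a group of 4 heavy atoms with one of 1 heavy atom while the free phenol and the rest of the shared core stay the same, so at this place on the ring the two substituents are interchangeable within the usual scatter of this measurement. No measurement shown here speaks to why these two groups read alike.

On these data alone, neither substituent in this pair has a hydrogen-bond donor or acceptor, so it remains open how an amine, a carboxylic acid or a longer chain would read at the same place. Compound 1 differs from compound 2 in more than one place, which leaves the separate contributions of the tosylate, the methoxyphenyl and the carbonyl unresolved.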